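A few compounds are considered here, and "the series" means these few. Any claim that something is new, unique, unknown or untested is made for them only; others in the source may bear on it.

Measured compounds:

Compound 1, `CN(C)CCn1cnnc1-c1cc(Oc2ccc(NC(=O)N/N=C/c3c(Cl)cccc3Cl)cc2F)ccn1`, gives 280 nM in a functional assay on HT-29 cells (Homo sapiens) for cytotoxicity, read by MTT assay, with a stated time of 72 h; on this read-out higher numbers stand for weaker inhibition and lower numbers for stronger inhibition.
Compound 2, `CN(C)CCn1cnnc1-c1cc(Oc2ccc(NC(=O)N/N=C/c3ccccc3)cc2F)ccn1`, gives 1120 nM.
Compound 3, `CN(C)CCn1cnnc1-c1cc(Oc2ccc(NC(=O)N/N=C/c3ccc(O)c(O)c3)cc2F)ccn1`, gives 1890 nM.

All three share one core and differ only in the aryl group attached to a carbon with a double bond to nitrogen. Compound 2 carries a plain phenyl there and stands second highest of the three numbers: compound 3 lies nearest, with its step of a 1.7-fold higher number from compound 2 to compound 3 (0.23 log units; within the scatter), while compound 1 lies furthest, with the step of a 4.0-fold higher number from compound 1 to compound 2 (0.60 log units; beyond the scatter).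

Compound 4, `COc1cc(/C=N/NC(=O)Nc2ccc(Oc3ccnc(-c4nncn4CCN(C)C)c3)c(F)c2)ccc1O`, has not yet been measured. It differs from compound 2 in one place: 4-hydroxy-3-methoxyphenyl in place of phenyl on a carbon with a double bond to nitrogen.

Among the measured compounds shown here, the step that bears on this change most directly is the one from compound 2 to compound 3, where a phenyl was also replaced by a ring bearing two oxygen groups, and that step was a 1.7-fold higher number from compound 2 to compound 3 (0.23 log units; within the scatter), within the scatter. Compound 1 shows that a ring change at this position can matter, as in a 6.8-fold higher number from compound 1 to compound 3 (0.83 log units; beyond the scatter), but the change to compound 4 adds oxygen groups rather than chlorines.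

For compound 4 a step of a 1.3-fold higher number from compound 2 to compound 4 (0.13 log units; within the scatter) is therefore expected, at most a small drift to a higher number. Compound 4 is estimated at 1500 nM, with a range from 700 nM to 3500 nM.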

Compound 4, half-maximal inhibitory concentration: 120 nM
Estimate against measurement, compound 4: 13-fold (1.10 log units) above, and the stated range ends above it.
By their numbers in this assay, from the lowest: compound 4; then compound 1; then compounds 2 and 3 (each within the scatter of the next).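

In this assay, among the compounds shown here, the aryl group on the carbon with a double bond to nitrogen proves more sensitive to oxygen groups than the earlier compounds suggested: swapping the plain phenyl for 4-hydroxy-3-methoxyphenyl gives a 9.3-fold lower number from compound 2 to compound 4 (0.97 log units; beyond the scatter), whereas the change to 3,4-dihydroxyphenyl gave only a 1.7-fold higher number from compound 2 to compound 3 (0.23 log units; within the scatter), which is within the scatter. The largest contrast comes from the smallest edit, a methyl in place of a hydrogen on one oxygen of the ring, which gives a 16-fold lower number from compound 3 to compound 4 (1.20 log units; beyond the scatter), so two rings that look much alike can behave very differently at this position. The 4-hydroxy-3-methoxyphenyl ring also goes past the best chlorinated ring shown, with a 2.3-fold lower number from compound 1 to compound 4 (0.37 log units; beyond the scatter), so among these four compounds the lowest number does not depend on chlorines.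

The compounds shown leave open whether the hydroxy group is needed beside the methoxy group, and whether an ethoxy group or an amine on the ring would hold the number this low. Nothing measured here gives a reason for these steps.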